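Shortening the Selenium Group: Compound 3 to Compound 4

The compounds below may be only part of what the source reports. "The series", "measured", "known", "first", "only" and "open" are said of these compounds alone.

Measured in a functional assay on HepG2 cells (Homo sapiens) for inhibition, read by MTT assay, with a stated time of 48 h; on this read-out lower numbers stand for stronger inhibition and higher numbers for weaker inhibition:
- compound 1 `COc1ccc(N(C)c2nc(C)nc3ccccc23)cc1C(=O)NCC[Se]C#N` gives 179 nM
- compound 2 `COc1ccc(N(C)c2nc(C)nc3ccccc23)cc1C(=O)OCCCC[Se]C#N` gives 975 nM
- compound 3 `COc1ccc(N(C)c2nc(C)nc3ccccc23)cc1[Se]C#N` gives 59 nM
- compound 4 `COc1ccc(N(C)c2nc(C)nc3ccccc23)cc1C[Se]C#N` is not yet measured

Compound 3 has the lowest number of the three at 59 nM, clearly below both others. Going on to compound 4 makes one change: a group of 4 heavy atoms (2 carbon, 1 nitrogen, 1 selenium; no ring) in place of a group of 3 heavy atoms (1 carbon, 1 nitrogen, 1 selenium; no ring), on an aromatic carbon. Going by the values given here, two measured steps bear on this, a 3.0-fold lower number from compound 1 to compound 3 (0.48 log units; beyond the scatter) and a 17-fold lower number from compound 2 to compound 3 (1.22 log units; beyond the scatter). In both, a smaller selenium-bearing group came with a lower number, and none of the three compounds goes against this. The group in compound 4 is only slightly larger than that in compound 3, so a small rise in this assay is expected, perhaps none beyond the scatter. The estimated step is a 1.7-fold higher number from compound 3 to compound 4 (0.23 log units; within the scatter). The estimate for compound 4 is 100 nM, with an expected range from 30 nM to 330 nM.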

Compound 4, half-maximal inhibitory concentration: 1110 nM
Beside the measured number, compound 4's estimate is 11-fold (1.05 log units) below it; measured number above the stated range.
By their numbers in this assay, from the lowest: compound 3; then compound 1; then compounds 2 and 4 (each within the scatter of the next).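

On this aromatic carbon, a slight enlargement of the selenium-bearing group is not a slight change (a 19-fold higher number from compound 3 to compound 4 (1.27 log units; beyond the scatter)). Group size alone therefore does not order these compounds: shrinking the amide chain gives a rise (a 6.2-fold higher number from compound 1 to compound 4 (0.79 log units; beyond the scatter)), and shrinking the ester chain gives no change beyond the scatter (a 1.1-fold higher number from compound 2 to compound 4 (0.06 log units; within the scatter)). Nothing available here accounts for the jump.

The compounds shown leave open whether a longer plain carbon chain ending in the same selenium group would raise the number further, or whether an ether oxygen at the linking point would bring it back down.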